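From bromo to fluoro at the limit of the assay

The compounds below may be only part of what the source reports. "The series", "measured", "known", "first", "only" and "open" are said of these compounds alone.

Measured values in an ADME assay on cells (Platelet, Homo sapiens) for inhibition, read by turbidimetry, with a stated time of 2 min (on this read-out lower numbers stand for stronger inhibition and higher numbers for weaker inhibition), are as follows
- compound 1 (`Cc1cc(C(=O)N/N=C/c2ccc([N+](=O)[O-])cc2)c2c(C)nn(-c3ccccc3)c2n1`) gives a limit (> 100000 nM)
- compound 2 (`Cc1cc(C(=O)N/N=C/c2ccc(O)cc2)c2c(C)nn(-c3ccccc3)c2n1`) gives a limit (> 100000 nM)
- compound 3 (`Cc1cc(C(=O)N/N=C/c2ccc(Br)cc2)c2c(C)nn(-c3ccccc3)c2n1`) gives a limit (> 100000 nM)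

Compound 3 therefore has a limit and not a number, and it shares this position with the others (the limit of > 100000 nM in this assay, at which 3 of the 3 values shown sit). Compound 4 (`Cc1cc(C(=O)N/N=C/c2ccc(F)cc2)c2c(C)nn(-c3ccccc3)c2n1`) carries fluoro in place of bromo on an aromatic carbon. Two measured steps also exchange this group (a step that the two limits leave unreadable from compound 1 to compound 3; a step that the two limits leave unreadable from compound 2 to compound 3). Neither has a readable size, so neither gives a direction, and no step beyond the scatter is expected in this assay. The expected change is small (a number no higher from compound 3 to compound 4 (the limit leaves the size open)). For compound 4 the estimated value is 100000 nM, with an expected range from 30000 nM to 300000 nM.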

Compound 4, half-maximal inhibitory concentration: > 100000 nM
Compound 4 ended at the assay's limit; the forecaster's own chance of this, stated with the estimate: 85%; the middle value lies on the limit itself.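

Compound 1, compound 2, compound 3 and compound 4 all give a limit and not a number in this assay, so no step among them can be read: the limit of > 100000 nM in this assay, at which 4 of the 4 values shown sit.

The compounds shown leave open which change to the shared core, if any, would give a readable number in this assay at all.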